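Benzamide series: amine substituent swap on the core of compound 3

The compounds below may be only part of what the source reports. "The series", "measured", "known", "first", "only" and "open" are said of these compounds alone.

Measured so far:
compound 1 `C=C(C)COc1ccc(C(=O)Nc2cccc(C)n2)cc1` gives 24700 nM
compound 2 `C=CCOc1ccc(C(=O)Nc2ccccn2)cc1` gives 61400 nM
compound 3 `CCCCNc1cccc(NC(=O)c2ccc(OCCC)cc2)n1` gives 77800 nM

In an in vitro assay on HEK-tsA201 cells for antagonist activity at Neuronal acetylcholine receptor; alpha3/beta4 (Homo sapiens), read by fluorescence and calcium flux (on this read-out higher numbers stand for weaker inhibition and lower numbers for stronger inhibition), compound 3 stands at the highest of the three numbers. Its gap to compound 2 lies within the scatter, so no order between those two can be read; its gap to compound 1 lies beyond the scatter, and compound 1 holds the lower number. Among the compounds with values here, no two of the measured compounds differ in a single place, so no counted step is available among them.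

Compound 4 `CCCOc1ccc(C(=O)Nc2cccc(NCc3ccccc3)n2)cc1` is not yet measured. It differs from compound 3 in one place: phenyl in place of propyl on a saturated chain carbon bound to a nitrogen on an aromatic ring. Within the data shown here, no measured pair shows what this change does in this assay, so the step from compound 3 to compound 4 is expected to be small, with no firm direction, and is estimated as a 1.4-fold lower number from compound 3 to compound 4 (0.15 log units; within the scatter). Compound 4 is therefore expected to give about 55000 nM in this assay, with a range from 15000 nM to 150000 nM.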

Compound 4, half-maximal inhibitory concentration: > 100000 nM
Compound 4: no number, only a limit (the forecaster's own chance of this, stated with the estimate: 20%); middle value at least 1.8-fold (0.25 log units) from the limit.
By their numbers in this assay, from the lowest: compound 1; then compounds 2 and 3 (each within the scatter of the next). At a limit, above all of these: compound 4.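

In this assay compound 4 gives > 100000 nM, which is a limit of the assay and not a number. Phenyl in place of propyl on a saturated chain carbon bound to a nitrogen on an aromatic ring gives the first counted step in the series, an at least 1.2-fold higher number from compound 3 to compound 4 (0.10 log units; that floor lies within the scatter), so this change shows no sign of a lower number. As far as these compounds go, only the floor of that step can be read, and its full size stays unknown: the limit of > 100000 nM in this assay, at which 1 of the 4 values shown sits.

Open, from the compounds shown here alone, is whether the ring or its aromatic character goes with this result, which cyclohexyl on the same carbon could separate from phenyl. Also open, going by these compounds, is what a longer chain such as hexyl, or a chain ending in an amine or a carboxylic acid, would do at this place.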